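This account rests on a few compounds, and the source may have more. Where it says the series, first, only, none or still open, it means among the compounds named here.

In an ADME assay on TZM-b1 cells (Homo sapiens) for cytotoxicity, read by XTT assay, with a stated time of 3 days (a lower number here means that less compound is tolerated, a higher number that more compound is tolerated), compound 1 `Cc1nc(C(NC(=O)C(=O)Nc2ccc(Cl)cc2)C2CCCN2)sc1CO` gives 12400 nM. Compound 2 `Cc1nc(C(NC(=O)C(=O)Nc2ccc(Cl)cc2)C2CCCCN2)sc1CO` gives > 22000 nM, which is a limit of the assay and not a number, so its position is known only as a limit. Compound 3 `Cc1ccc(NC(=O)C(=O)NC(c2nc(C)c(CO)s2)C2CCCCN2)c(F)c1` differs from compound 2 in one place, on an amide-type nitrogen: 2-fluoro-4-methylphenyl in place of 4-chlorophenyl on an amide-type nitrogen. Among the measured compounds shown here, the only measured step, an at least 1.7-fold higher number from compound 1 to compound 2 (0.24 log units; that floor lies within the scatter), lies elsewhere in the structure, and its floor lies within the scatter. For the measured compounds named here, that step gives no size for the change at the amide-type nitrogen, and no measured step covers this change. No step beyond the scatter is therefore expected in this assay, and no direction is expected either. The expected step is a number no higher from compound 2 to compound 3 (the limit leaves the size open). For compound 3 the estimated value is 22000 nM, with an expected range from 10000 nM to 48000 nM.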

Compound 3, half-maximal cytotoxic concentration: > 88000 nM
Compound 3: a limit, no number; the forecaster's own chance of this, stated with the estimate: 55%; middle value at least 4.0-fold (0.60 log units) away from the limit.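

Compound 2 and compound 3 both stand only as limits in this assay, not as numbers, so no step can be read between them. The compounds shown leave open the size and direction of the change from 4-chlorophenyl to 2-fluoro-4-methylphenyl on the amide-type nitrogen.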